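Carbamate in place of an amide on a pyrazole core

A few compounds are considered here, and "the series" means these few. Any claim that something is new, unique, unknown or untested is made for them only; others in the source may bear on it.

Two compounds share the same core and differ only in the group on the carbonyl carbon. Compound 1 `Cc1cc(NC(=O)CC2CCCCC2)nn1Cc1cc(Cl)ccc1OCc1ccccc1` gives 6.31 nM in an assay on CHO-K1 cells for displacement of a labelled ligand from prostaglandin E2 receptor EP1 subtype (Homo sapiens); a higher number here means a weaker inhibitor, a lower number a stronger inhibitor. Among the compounds with values here, compound 2 `Cc1cc(NC(=O)C2CCOCC2)nn1Cc1cc(Cl)ccc1OCc1ccccc1` gives 63.1 nM in this assay, the highest of the two numbers; the step of a 10-fold higher number from compound 1 to compound 2 (1.00 log units; beyond the scatter) is the only measured step in this set. Compound 3 `Cc1cc(NC(=O)OC(C)(C)C)nn1Cc1cc(Cl)ccc1OCc1ccccc1` has not yet been measured. It differs from compound 2 in that (tert-butoxy in place of oxan-4-yl on a carbonyl carbon). Within the data shown here, the one measured step, which exchanged cyclohexylmethyl for oxan-4-yl, does not cover the change to tert-butoxy, so there is no direct precedent for it. The measured step shows that this position can move the number by a modest amount, but gives no direction for a group with no ring. Compound 3 is therefore expected to show no step beyond the scatter, with the estimated step of a 1.1-fold lower number from compound 2 to compound 3 (0.02 log units; within the scatter). Compound 3 is estimated at 60 nM, with a range from 15 nM to 300 nM in this assay.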

Compound 3, half-maximal inhibitory concentration: 25.1 nM
The estimate for compound 3 lay 2.4-fold (0.38 log units) above the measured number, within the range that was stated.
By their numbers in this assay, from the lowest: compound 1; then compound 3; then compound 2.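

Moving to tert-butoxy on the carbonyl carbon gives a 2.5-fold lower number from compound 2 to compound 3 (0.40 log units; beyond the scatter) in this assay, so a group with no ring can give a lower number at this position than oxan-4-yl does. The same group does not match cyclohexylmethyl, with a 4.0-fold higher number from compound 1 to compound 3 (0.60 log units; beyond the scatter) on that comparison, which places compound 3 between the other two compounds and gives this position a graded order across three groups rather than a simple contrast between two. No measurement offered here accounts for this order, and the change of tert-butoxy for oxan-4-yl alters both the ring and the atom bound to the carbonyl carbon, so the two cannot be separated.

The compounds shown leave open whether the lower number of compound 3 goes with the oxygen on the carbonyl carbon or with the branched carbon group, a question that a tert-butyl group placed directly on the carbonyl carbon would address. They also leave open how a cyclohexylmethoxy group or an amine on this carbon would compare with cyclohexylmethyl.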